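The source may hold more compounds than are shown below. What is called first, only, known or untested is meant among the compounds shown, and "the series" means these compounds.

Of the compounds shown here, three built on one shared core have been measured in a functional assay on DLD-1 cells (Homo sapiens) for antiproliferative activity, read by CellTiter-Glo, with a stated time of 72 h; on this read-out lower numbers stand for stronger inhibition and higher numbers for weaker inhibition. Compound 1 `CC1CCN(C2CCN(S(=O)(=O)c3ccc(F)cc3F)CC2)CC1`, which carries a 2,4-difluorophenyl group on the sulfonyl sulfur, gives 102 nM. Compound 2 `CC1CCN(C2CCN(S(=O)(=O)c3cnc(Cl)s3)CC2)CC1` gives 1800 nM, so that an 18-fold higher number from compound 1 to compound 2 (1.25 log units; beyond the scatter). Compound 3 `CC1CCN(C2CCN(S(=O)(=O)c3cccnc3F)CC2)CC1` is reported only at the assay limit, > 5000 nM, and not as a number. Against the other two this places compound 3 at the weak end: an at least 49-fold higher number from compound 1 to compound 3 (1.69 log units; beyond the scatter) and an at least 2.7-fold higher number from compound 2 to compound 3 (0.44 log units; beyond the scatter).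

Compound 4 `CC1CCN(C2CCN(S(=O)(=O)c3ccc(Cl)nc3)CC2)CC1` has not yet been measured. It differs from compound 3 in one place: 6-chloropyridin-3-yl in place of 2-fluoropyridin-3-yl on a sulfonyl sulfur. Both steps that lead into compound 3 were large and weakening, and nothing measured here shows how moving the ring nitrogen and swapping fluorine for chlorine within a pyridinyl group acts on its own. Among the measured compounds shown here, the only aryl group carrying a chlorine, in compound 2, gave a weak but countable value. Compound 4 is therefore expected to remain weak, with an at least 1.2-fold lower number from compound 3 to compound 4 (0.09 log units; that floor lies within the scatter) as an estimate; compound 4 is estimated at 4000 nM, likely between 800 nM and 20000 nM.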

Compound 4, half-maximal inhibitory concentration: 3700 nM
Compound 4: middle estimate off by 1.1-fold (0.03 log units), on the high side, within the range that was stated.
By their numbers in this assay, from the lowest: compound 1; then compound 2; then compound 4. At a limit, above all of these: compound 3.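

Among the compounds shown here, compound 4 gives the first countable number for a pyridinyl group on the sulfonyl sulfur, and the 2,4-difluorophenyl group keeps a large lead over it, with a 36-fold higher number from compound 1 to compound 4 (1.56 log units; beyond the scatter). Against the other chlorine-bearing group, 2-chloro-1,3-thiazol-5-yl, the gap is only modest, with a 2.1-fold higher number from compound 2 to compound 4 (0.31 log units; beyond the scatter), so all three groups that replace 2,4-difluorophenyl here fall far behind it. Compound 3 is held only at a limit of the assay, so the change to 6-chloropyridin-3-yl can be sized only as a floor, an at least 1.3-fold lower number from compound 3 to compound 4 (0.13 log units; that floor lies within the scatter), and its true size remains unknown: the limit of > 5000 nM in this assay, at which 1 of the 4 values shown sits.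

Still open, as far as these compounds go, is whether the loss follows the ring nitrogen or the halogen, a question that a plain phenyl or a chlorophenyl group on the same sulfonyl sulfur could help separate. From the compounds shown here alone, how a nitrile or a methoxy group on the pyridinyl ring would behave also remains open.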